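The source may hold more compounds than are shown below. What is called first, only, known or untested is meant among the compounds shown, and "the series" means these compounds.

Measured so far in a physicochemical assay for solubility, with a stated time of 3 days, at pH 2; a lower number here means a less soluble compound, a higher number a more soluble compound:
Compound 1 `CN1CCC(Oc2ccc(-c3nc4cc(C(N)=O)ccc4[nH]3)cc2)C1`: "not determined" (no result reported)
Compound 2 `NC(=O)c1ccc2[nH]c(-c3ccc(OCCCN4CCCCC4)cc3)nc2c1`: > 400000 nM
Compound 3 `CN1CCC(Oc2ccc(-c3nc4cc(C(N)=O)ccc4[nH]3)cc2)CC1`: > 400000 nM

Compound 3 has no exact reading in this assay. Compound 3 stands at > 400000 nM, which is a limit of the assay and not a number. Compound 2 gives the same limit, > 400000 nM. The results shown therefore gather at the limit of > 400000 nM in this assay, at which 2 of the 3 values shown sit, while compound 1 offers no result to compare.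

Compound 4 `NC(=O)c1ccc2[nH]c(-c3ccc(OCC4CCNCC4)cc3)nc2c1` has not yet been measured. Moving to it from compound 3, (piperidin-4-yl)methyl takes the place of 1-methylpiperidin-4-yl on an oxygen on an aromatic ring ((piperidin-4-yl)methyl in place of 1-methylpiperidin-4-yl on an oxygen on an aromatic ring). The two compounds have the same atoms, joined differently.

Among the measured compounds shown here, only one measured step bears on this change, as it also alters the group on an oxygen on an aromatic ring: a step that the two limits leave unreadable from compound 2 to compound 3. It gives neither a size nor a direction to carry over. No change beyond the usual scatter is therefore expected, and the assay may well report only a limit again. The expected step is a number no higher from compound 3 to compound 4 (the limit leaves the size open). Compound 4 is estimated at 400000 nM, with an expected range from 200000 nM to 800000 nM.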

Compound 4, solubility: > 400000 nM
Compound 4 was reported as a limit; the forecaster's own chance of this, stated with the estimate: 75%; the middle value lies on the limit itself.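

Compound 2, compound 3 and compound 4 all report a limit rather than a number in this assay, so the steps among them cannot be read: the limit of > 400000 nM in this assay, at which 3 of the 4 values shown sit.

The compounds shown leave open how far apart these three lie in this assay, and whether changing the group on an oxygen on an aromatic ring alters the reading at all.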